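A few compounds are considered here, and "the series" means these few. Any claim that something is new, unique, unknown or untested is made for them only; others in the source may bear on it.

Measured compounds and their values in an assay for inhibition of Indoleamine 2,3-dioxygenase 1 (Homo sapiens), with stated times of 10 min and 60 min, tested at 100 uM; a higher number here means a stronger effect of the compound at the concentration tested, a lower number a weaker effect:
- compound 1 `NCCn1ncc2c(NCc3ccccc3[N+](=O)[O-])cc(C(F)(F)F)cc21` gives 30%
- compound 2 `FC(F)(F)c1cc(NCc2cccc(Br)c2)c2cn[nH]c2c1` gives 51%

Compound 1 stands at the lowest of the two numbers shown. Its nearest neighbour is compound 2, whose value lies higher by a margin that is beyond the usual scatter of this kind of measurement; the two compounds differ in more than one place, so only their two values can be compared, not a single change.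

The step considered here leads from compound 1 to compound 3 `O=[N+]([O-])c1ccccc1CNc1cc(C(F)(F)F)cc2[nH]ncc12`, which has not yet been tested in this assay. The change is hydrogen in place of 2-aminoethyl on an aromatic nitrogen. Compound 2 also carries a hydrogen on that aromatic nitrogen, but its other differences from compound 3 prevent a direct reading of how much of its higher value comes from that feature.

Going by the values given here, with no single-change step available, a modest rise is expected, of size a number 10 percentage points higher from compound 1 to compound 3 (within the scatter) in this assay, with a real chance that it stays within the scatter. Compound 3 is therefore estimated at 40%, in a range from 22% to 60%.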

Compound 3, a percentage reported as inhibition, at one concentration (the size of the read-out at that concentration, not a potency): 76%
The estimate for compound 3 lay 36 percentage points below the measured number, outside the stated range (above it).
By their numbers in this assay, from the lowest: compound 1; then compound 2; then compound 3.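

In this assay, going by these compounds alone, the step gives the first reading of one single change at this place, on an aromatic nitrogen of the five-membered ring: hydrogen in place of 2-aminoethyl gives a number 46 percentage points higher from compound 1 to compound 3 (beyond the scatter), with the rest of the molecule unchanged. The earlier pair, compound 1 and compound 2, differed in more than one place, so the part played by the hydrogen could not be separated from their other differences. This step shows that, with this shared core and at the tested concentration, the compound with hydrogen at this nitrogen inhibits far more than the one with 2-aminoethyl, although no measurement at hand bears on why the step is so large.

The compounds shown leave open whether any group on this nitrogen lowers the inhibition or only 2-aminoethyl does. A small methyl, a plain ethyl chain without the amine, or a longer chain ending in an amine or a carboxylic acid at the same place would show whether the drop follows the chain, its amine, or both.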